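This account rests on a few compounds, and the source may have more. Where it says the series, first, only, none or still open, it means among the compounds named here.

Measured compounds:
Compound 1 `Cc1ccc(-c2cc(NO)c(C(=O)Nc3ccccc3)c(=O)o2)cc1` — > 20000 nM
Compound 2 `O=C(NCc1ccccc1)c1c(NO)cc(-c2ccc(F)cc2)oc1=O` — > 20000 nM

Both measurements come from an ADME assay on Huh-7 cells (Homo sapiens) for cytotoxicity, read by a luciferase reporter and WST assay, with a stated time of 3 days; on this read-out lower numbers stand for higher toxicity in this test and higher numbers for lower toxicity in this test. In this assay compound 1 gives > 20000 nM, which is a limit of the assay and not a number. In this assay compound 2 gives > 20000 nM, again a limit rather than a number. For the measured compounds named here, compound 2 therefore stands at the same point as the only other value shown: the limit of > 20000 nM in this assay, at which 2 of the 2 values shown sit. Going by the values given here, no step between two measured compounds is available, so no measured change can be described.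

Compound 3 `Cc1ccc(-c2cc(NO)c(C(=O)NCc3ccccc3)c(=O)o2)cc1` is the next compound. It differs from compound 2 by methyl in place of fluoro on an aromatic carbon. Both measured compounds sit at the limit, and the change is a single heavy atom swapped for another on the outer ring, so no step beyond the usual scatter is expected in either direction. Compound 3 is expected to give 30000 nM in this assay, within a range from 15000 nM to 80000 nM. This estimate means an expected step that the limit leaves unreadable from compound 2 to compound 3, most likely reported again as a limit.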

Compound 3, half-maximal cytotoxic concentration: > 20000 nM
Compound 3 was reported as a limit; the forecaster's own chance of this, stated with the estimate: 85%; the middle value lies beyond the limit too.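

Compound 3 ends at a limit, as do compound 1 and compound 2, so neither step to compound 3 can be read: the limit of > 20000 nM in this assay, at which 3 of the 3 values shown sit.

The compounds shown leave open whether methyl in place of fluoro, or benzyl in place of phenyl, changes the result in this assay at all.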